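The source may report more compounds than this note shows. Statements on the series, on what has been measured and on what is new or still open speak of the compounds shown alone.

Of the compounds shown here, three on a shared core have been measured so far in a functional assay on PC-3 cells (Homo sapiens) for cytotoxicity, read by WST assay, with a stated time of 3 days (a higher number here means a weaker inhibitor, a lower number a stronger inhibitor), for this series. Compound 1 `Cn1ccnc1/C=C/C(=O)/C=C/c1coc2ccccc2c1=O` gives 2800 nM there, compound 2 `CCn1ccnc1/C=C/C(=O)/C=C/c1coc2ccccc2c1=O` gives 1800 nM there, and compound 3 `CC(C)CCn1ccnc1/C=C/C(=O)/C=C/c1coc2ccccc2c1=O` gives 3600 nM there. Compound 3 stands within the scatter of both others, shown by a 1.3-fold higher number from compound 1 to compound 3 (0.11 log units; within the scatter) and by a 2.0-fold higher number from compound 2 to compound 3 (0.30 log units; within the scatter) on the same nitrogen. Compound 4 `CCCC(C)n1ccnc1/C=C/C(=O)/C=C/c1coc2ccccc2c1=O` carries 1-methylbutyl in place of isopentyl on an aromatic nitrogen, a difference counted as 1-methylbutyl in place of isopentyl on an aromatic nitrogen in full. Among the measured compounds shown here, no measured compound carries 1-methylbutyl. With a 1.6-fold lower number from compound 1 to compound 2 (0.19 log units; within the scatter) as well, every measured step stayed within the scatter, so the expected step is a 1.3-fold lower number from compound 3 to compound 4 (0.11 log units; within the scatter) and none beyond the scatter in this assay is expected here. Compound 4 is estimated at 2800 nM within an expected range of 1300 nM to 5500 nM overall.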

Compound 4, half-maximal inhibitory concentration: 3200 nM
For compound 4 the middle estimate is 1.1-fold (0.06 log units) below the measured one; low and high end bracket the measured number.
By their numbers in this assay, from the lowest: compounds 2, 1, 4 and 3 (each within the scatter of the next).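

In this assay, 1-methylbutyl in place of isopentyl on the aromatic nitrogen gives a 1.1-fold lower number from compound 3 to compound 4 (0.05 log units; within the scatter) and thus no separation between these two arrangements of the same atoms. The larger comparisons also stay small, with a 1.8-fold higher number from compound 2 to compound 4 (0.25 log units; within the scatter) and a 1.1-fold higher number from compound 1 to compound 4 (0.06 log units; within the scatter) on the same nitrogen, so the new group adds no step beyond the scatter. No evidence bearing on this result is available. Still open, going by these compounds, is whether a benzyl group, or a chain ending in an amine or a carboxylic acid, on this nitrogen would produce a step beyond the scatter.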